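From compound 3 to compound 4: one group swapped

This account rests on a few compounds, and the source may have more. Where it says the series, first, only, none or still open, it means among the compounds named here.

Measured in a functional assay on DU-145 cells (Homo sapiens) for inhibition, read by trypan blue exclusion, with a stated time of 72 h; a higher number here means a weaker inhibitor, a lower number a stronger inhibitor
- compound 1 `Cn1c(=O)c(S(=O)(=O)c2ccc(F)cc2)cc2cnc(Nc3ccc4cc[nH]c4c3)nc21` gives 10000 nM
- compound 2 `Cc1ccc(S(=O)(=O)c2cc3cnc(Nc4cnc5[nH]ccc5c4)nc3n(C)c2=O)cc1` gives 25000 nM
- compound 3 `Cn1c(=O)c(S(=O)(=O)c2ccc(F)cc2)cc2cnc(Nc3ccc4[nH]cnc4c3)nc21` gives 10000 nM

Compound 3 stands level with compound 1, together the lowest of the three numbers, and compound 2 gives a higher number. Compound 4 `Cn1c(=O)c(S(=O)(=O)c2ccc(F)cc2)cc2cnc(Nc3cnc4[nH]ccc4c3)nc21` has the same atoms as compound 3, joined differently: a group of 9 heavy atoms (7 carbon, 2 nitrogen; one five-membered aromatic ring with 1 hetero atom, one six-membered aromatic ring with 1 hetero atom) in place of a group of 9 heavy atoms (7 carbon, 2 nitrogen; one five-membered aromatic ring with 2 hetero atoms, one six-membered aromatic ring of carbon only), on a nitrogen on an aromatic ring. Among the measured compounds shown here, the one measured swap at this place shows no change at the digits printed from compound 1 to compound 3 (within the scatter), which points to little change. Compound 2 already carries the entering group but also differs from compound 4 elsewhere. Compound 2 gives 25000 nM, which leans slightly upward. The expected result is a 1.4-fold higher number from compound 3 to compound 4 (0.15 log units; within the scatter) in this assay, a small rise that stays within the scatter. For compound 4 the estimated value is 14000 nM, with an expected range from 6000 nM to 30000 nM when measured.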

Compound 4, half-maximal inhibitory concentration: 500 nM
For compound 4 the middle estimate is 28-fold (1.45 log units) above the measured one, and the stated range ends above it.
By their numbers in this assay, from the lowest: compound 4; then compounds 1 and 3 (each within the scatter of the next); then compound 2.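

In this assay, the group on the nitrogen matters far more than the step of no change at the digits printed from compound 1 to compound 3 (within the scatter) suggested: the group with a hetero atom in its six-membered ring gives a 20-fold lower number from compound 3 to compound 4 (1.30 log units; beyond the scatter) and a 20-fold lower number from compound 1 to compound 4 (1.30 log units; beyond the scatter) against the two groups whose six-membered ring is carbon only. That group is not enough alone, since fluoro in place of methyl on an aromatic carbon gives a 50-fold lower number from compound 2 to compound 4 (1.70 log units; beyond the scatter) with the group kept. Nothing available explains these drops. From the compounds shown here alone, whether chloro or methoxy could stand in for fluoro remains open.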